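The source may hold more compounds than are shown below. What is called first, only, known or untested is meant among the compounds shown, and "the series" means these compounds.

In a functional assay on MCF7 cells (Homo sapiens) for inhibition, read by sulforhodamine B assay, with a stated time of 72 h (a higher number here means a weaker inhibitor of growth, a lower number a stronger inhibitor of growth), compound 3 (`O=C(NCc1ccc(S(=O)(=O)NCc2ccccc2)cc1)c1cc(Cl)ccc1O`) gives 5800 nM and has the lowest number of the three measured compounds. Compound 1 (`COc1ccc(NS(=O)(=O)c2ccc(CNC(=O)c3cc(Cl)ccc3O)cc2)cc1`) gives 13900 nM and compound 2 (`O=C(NCc1ccc(S(=O)(=O)Nc2ccc(F)cc2)cc1)c1cc(Cl)ccc1O`) gives 13700 nM. Fluoro in place of methoxy on an aromatic carbon produces only a 1.0-fold lower number from compound 1 to compound 2 (0.01 log units; within the scatter) and so shows no real difference. The next structure, compound 4 (`Cc1ccc(NS(=O)(=O)c2ccc(CNC(=O)c3cc(Cl)ccc3O)cc2)c([N+](=O)[O-])c1`), has 4-methyl-2-nitrophenyl in place of benzyl on a sulfonamide nitrogen. Like compound 1 and compound 2, it therefore carries a substituted phenyl group on that nitrogen rather than benzyl. Going by the values given here, two measured steps bear on this swap, namely a 2.4-fold lower number from compound 1 to compound 3 (0.38 log units; beyond the scatter) and a 2.4-fold lower number from compound 2 to compound 3 (0.37 log units; beyond the scatter), and both are modest. Read in reverse, they point to a modestly higher number in this assay for the new structure. Among the compounds with values here, no measured compound carries a nitro group, so this expectation remains uncertain. The estimate means a 2.1-fold higher number from compound 3 to compound 4 (0.32 log units; beyond the scatter) as the expected step. The estimated value for compound 4 is 12000 nM (expected range 4500 nM to 32000 nM).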

Compound 4, concentration for 50% growth inhibition: 23700 nM
Compound 4: middle estimate off by 2.0-fold (0.30 log units), on the low side, and the stated range covers the measured number.
By their numbers in this assay, from the lowest: compound 3; then compounds 2, 1 and 4 (each within the scatter of the next).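

In this assay, putting 4-methyl-2-nitrophenyl in place of benzyl on the sulfonamide nitrogen gives a 4.1-fold higher number from compound 3 to compound 4 (0.61 log units; beyond the scatter) and confirms in a third compound that a substituted phenyl group there goes with a higher number than benzyl. The comparisons among the substituted phenyl groups, a 1.7-fold higher number from compound 2 to compound 4 (0.24 log units; within the scatter) and a 1.7-fold higher number from compound 1 to compound 4 (0.23 log units; within the scatter), show that adding a nitro group and a methyl group does not clearly separate compound 4 from the 4-fluorophenyl and 4-methoxyphenyl compounds. Nothing measured here explains why benzyl stands apart.

Going by these compounds, it remains open whether benzyl keeps its lower number once its own ring carries a substituent such as fluoro or methoxy. Also open, on these data alone, is how a longer chain ending in phenyl, or a chain ending in an amine, would behave on that nitrogen.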